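Swapping the piperidine aryl group: from compound 1 to compound 4

The source may hold more compounds than are shown below. What is called first, only, known or untested is meant among the compounds shown, and "the series" means these compounds.

Compound 1 `Cc1cccc(NC(=O)CN2CCC(c3ccc(O)cc3)CC2)c1` was tested in a functional assay on HEK293 cells for agonist activity at D(4) dopamine receptor (Homo sapiens), read by FLIPR (a higher number here means a larger maximal response, a lower number a smaller maximal response), where compound 1 gives 60%. Two related compounds were run alongside: compound 2 `CSc1cccc(NC(=O)CN2CCC(c3cccc[n+]3[O-])CC2)c1` gives 56%, and compound 3 `Cc1ccc(Cl)cc1NC(=O)CN1CCC(c2cccc[n+]2[O-])CC1` gives 58%. The number for compound 1 is the highest of the three, yet both other values lie within the scatter of it, so none of the three stands apart. Within the data shown here, the one measured step, a number 2 percentage points higher from compound 2 to compound 3 (within the scatter), concerns the amide-type nitrogen and not the saturated ring carbon.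

Compound 4 `Cc1cccc(NC(=O)CN2CCC(c3cccc(C#N)n3)CC2)c1` differs from compound 1 only there: 6-cyanopyridin-2-yl in place of 4-hydroxyphenyl on a saturated ring carbon. Among the measured compounds shown here, no measured step touches this position, and the amide-side step was flat. Compound 4 is therefore expected to show a number 3 percentage points lower from compound 1 to compound 4 (within the scatter), giving an estimated 57%, in a range from 40% to 72%.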

Compound 4, largest response reached (reported as efficacy), in percent of the reference or control that the assay uses: 42%
Estimate against measurement, compound 4: 15 percentage points above, within the range that was stated.
By their numbers in this assay, from the lowest: compound 4; then compounds 2, 3 and 1 (each within the scatter of the next).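

In this assay, among these compounds, the saturated ring carbon proves to be a position where the maximal response can move: a number 18 percentage points lower from compound 1 to compound 4 (beyond the scatter), whereas the one earlier step, on the amide-type nitrogen, stayed within the scatter. This single change removes the hydroxyl group and brings in both a ring nitrogen and a nitrile, so the step cannot assign the drop to any one of them. No measurement available here explains it. The compounds shown leave open which of these features matters, and what a plain phenyl or an unsubstituted pyridin-2-yl group would give on this carbon.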